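A Second Fluoro on Compound 3 at the Assay Limit

The source may report more compounds than this note shows. Statements on the series, on what has been measured and on what is new or still open speak of the compounds shown alone.

Of the compounds shown here, three have been measured so far in a functional assay on ECV-304 cells (Homo sapiens) for cytotoxicity; a lower number here means a stronger inhibitor, a higher number a weaker inhibitor. Compound 1 (`COc1ccc(S(=O)(=O)NN2C(=S)S/C(=C\c3ccc(Cl)c(Cl)c3)C2O)cc1`) gives > 50000 nM as a limit. Compound 2 (`O=S(=O)(NN1C(=S)S/C(=C\c2ccc(Cl)c(Cl)c2)C1O)c1ccc(Cl)cc1`) gives > 50000 nM as a limit as well. Compound 3 (`O=C1/C(=C/c2ccccc2F)SC(=S)N1NS(=O)(=O)c1ccccc1`), the starting point here, gives > 50000 nM as a limit too, so it cannot be ranked against the other two. The whole set rests on (the limit of > 50000 nM in this assay, at which 3 of the 3 values shown sit), and none of the three has yet returned a plain number.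

Compound 4 (`O=C1/C(=C/c2cc(F)ccc2F)SC(=S)N1NS(=O)(=O)c1ccccc1`) departs from compound 3 by a single change: fluoro in place of hydrogen on an aromatic carbon, which turns 2-fluorophenyl into 2,5-difluorophenyl. Within the data shown here, the one measured step that bears on it is a step that the two limits leave unreadable from compound 1 to compound 2, with chloro in place of methoxy on an aromatic carbon, and it offers no size to carry over. Since compound 3 gives > 50000 nM as a limit, compound 4 is expected to stay at that same limit. The expected change is a number no higher from compound 3 to compound 4 (the limit leaves the size open), with no direction and no size beyond the scatter. Compound 4 is estimated at 50000 nM, with an expected range from 25000 nM to 100000 nM.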

Compound 4, half-maximal inhibitory concentration: > 50000 nM
Compound 4 ended at the assay's limit (the forecaster's own chance of this, stated with the estimate: 85%); the middle value sits exactly at the limit.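

Among these compounds, compound 3 and compound 4 both rest at a limit in this assay rather than at a plain number, so no step between them can be read. Still open is how far the second fluoro of 2,5-difluorophenyl moves the value, and whether any compound shown gives a plain number at all: the limit of > 50000 nM in this assay, at which 4 of the 4 values shown sit.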